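Swapping the piperazine of compound 1 for a chloroanilino group

The source may hold more compounds than are shown below. What is called first, only, known or untested is meant among the compounds shown, and "the series" means these compounds.

Compound 1, with the structure `CN1CCN(c2nc(Cl)nc3c2ncn3Cc2ccc(C(=O)Nc3ccccc3N)cc2)CC1`, gives 72.8% in a functional assay on HCT-116 cells (Homo sapiens) for antiproliferative activity, read by CCK-8 assay, with a stated time of 72 h, tested at 8 uM; on this read-out lower numbers stand for a weaker effect and higher numbers for a stronger effect at the one concentration tested. That is the higher of the two numbers recorded so far: compound 2, with the structure `CCCCn1cnc2c(NCc3ccc(C(=O)Nc4ccccc4N)cc3)nc(Cl)nc21`, gives 40.9% in this assay, a number that sits well below compound 1, farther apart than repeated measurements usually scatter. Compound 2 differs from compound 1 in more than one place, so these two values by themselves do not show which part of the molecule carries the difference.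

Compound 3, with the structure `Nc1ccccc1NC(=O)c1ccc(Cn2cnc3c(Nc4cccc(Cl)c4)nc(Cl)nc32)cc1`, has not yet been tested in this assay. It differs from compound 1 in a single place: (3-chlorophenyl)amino in place of 4-methylpiperazin-1-yl on an aromatic carbon. Among the compounds with values here, no pair of measured compounds changes only this group, so the size of the step is open. The expectation is a moderate change in this assay, most likely downward but possibly none beyond the scatter, giving a step from compound 1 to compound 3 of about a number 12.8 percentage points lower from compound 1 to compound 3 (beyond the scatter). For compound 3 the estimated value is 60%, with a range from 35% to 85%.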

Compound 3, a percentage reported as inhibition, at one concentration (the size of the read-out at that concentration, not a potency): 78.4%
The estimate for compound 3 lay 18.4 percentage points below the measured number; low and high end bracket the measured number.
By their numbers in this assay, from the lowest: compound 2; then compounds 1 and 3 (each within the scatter of the next).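

In this assay, within the data shown here, putting (3-chlorophenyl)amino in place of 4-methylpiperazin-1-yl on this aromatic carbon gives a number 5.6 percentage points higher from compound 1 to compound 3 (within the scatter) and thus no step that can be told apart from ordinary repeat variation. This shows that, for this pair, two quite different groups can occupy this position and give readings within the scatter of each other: one is a six-membered non-aromatic ring with 2 hetero atoms and 0 hydrogen-bond donors, the other a six-membered aromatic ring of carbon only, carrying a chlorine and linked through a group with 1 hydrogen-bond donor. No measurement is at hand that explains why the two groups read alike.

From the compounds shown here alone, whether a plain phenylamino group, a morpholine ring or a small primary amine at this place would also read like compound 1 and compound 3 remains open, as does the part played by the chlorine on the aromatic ring. Going by these compounds, a reading at one concentration gives the size of an effect rather than a potency, so it also stays open whether compound 1 and compound 3 would match across a range of concentrations.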